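Cytotoxicity notes: from compound 2 to compound 3

The source may report more compounds than this note shows. Statements on the series, on what has been measured and on what is new or still open speak of the compounds shown alone.

Of the compounds shown here, two have been measured in an ADME assay on HEp-2 cells (Homo sapiens) for cytotoxicity, read by CCK-8 assay, with a stated time of 5 days; a higher number here means that more compound is tolerated, a lower number that less compound is tolerated. Compound 1 `COc1ccc2nc(N3CCCc4ccccc4C3)cc(NCCN)c2c1` gives 4800 nM. Compound 2 `Cc1ccc2nc(N3CCCc4ccc(F)cc4C3)cc(NCCN(C)C)c2c1` gives 89000 nM, the higher of the two numbers; the gap to compound 1 is beyond the scatter, but the two structures differ in several places, so nothing ties it to one change.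

Compound 3 `Cc1ccc2nc(N3CCCc4ccc(F)cc4C3)cc(NC3(CN)COC3)c2c1` has not yet been measured. Relative to compound 2 it carries 3-(aminomethyl)oxetan-3-yl in place of 2-(dimethylamino)ethyl on a nitrogen on an aromatic ring. Among the compounds with values here, no measured pair isolates a change of this kind, so the size and direction of the step are open. The step from compound 2 to compound 3 is expected to be a 1.5-fold lower number from compound 2 to compound 3 (0.17 log units; within the scatter) in this assay, none beyond the scatter, because compound 2 gives 89000 nM and no measured change to the group on that nitrogen is known. Compound 3 is therefore estimated at 60000 nM, with a range from 15000 nM to 200000 nM.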

Compound 3, half-maximal cytotoxic concentration: 86000 nM
Estimate against measurement, compound 3: 1.4-fold (0.16 log units) below; low and high end bracket the measured number.
By their numbers in this assay, from the lowest: compound 1; then compounds 3 and 2 (each within the scatter of the next).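

Within the data shown here, this is the first pair that differs in one place, and it gives a direct reading for the group on a nitrogen on an aromatic ring. In this assay, putting 3-(aminomethyl)oxetan-3-yl in place of 2-(dimethylamino)ethyl gives a 1.0-fold lower number from compound 2 to compound 3 (0.01 log units; within the scatter), so this position accepts a four-membered ring with one hetero atom and an added hydrogen-bond donor with no reading outside the scatter. Nothing measured on these compounds offers an explanation for this result.

On these data alone, whether the same holds for a longer chain, such as 3-(dimethylamino)propyl, or for a carboxylic acid on this nitrogen remains open. Compound 1 differs from compound 2 and compound 3 in several places, so its lower number cannot yet be tied to any one of them.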